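Fluoro in place of methyl: compound 2 to compound 3

The compounds below may be only part of what the source reports. "The series", "measured", "known", "first", "only" and "open" are said of these compounds alone.

Of the compounds shown here, two have been read so far in an ADME assay on HUVEC cells (Homo sapiens) for inhibition, read by CCK-8 assay, with a stated time of 24 h, in the presence of a further agent that is not named here; a lower number here means a stronger inhibitor, a higher number a weaker inhibitor. Compound 1 (`O=C1Nc2ccccc2/C1=C/c1ccc(-c2cn(-c3cccc(Cl)c3)nn2)cc1`) gives > 20000 nM, which is a limit of the assay and not a number. Among the measured compounds shown here, compound 2 (`Cc1ccc(-n2cc(-c3ccc(/C=C4\C(=O)Nc5ccc(F)cc54)cc3)nn2)cc1`) gives 13800 nM, the only true number in the set, so its standing rests on that single reading.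

Compound 3 (`O=C1Nc2ccc(F)cc2/C1=C/c1ccc(-c2cn(-c3ccc(F)cc3)nn2)cc1`) departs from compound 2 in one place: fluoro in place of methyl on an aromatic carbon, with fluoro in place of methyl on an aromatic carbon, para to a large group. For the measured compounds named here, no measured step covers this change. No shift beyond the usual scatter is therefore expected in this assay, and no direction is predicted. The expected 1.0-fold higher number from compound 2 to compound 3 (0.01 log units; within the scatter) is small. A report of compound 3 as a limit remains possible. For compound 3 the estimated value is 14000 nM, with an expected range of 7000 nM to 20000 nM.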

Compound 3, half-maximal inhibitory concentration: > 20000 nM
Compound 3: no number, only a limit; the forecaster's own chance of this, stated with the estimate: 25%; middle value at least 1.4-fold (0.15 log units) away from the limit.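

In this assay, among the compounds shown here, the change from 4-methylphenyl to 4-fluorophenyl gives an at least 1.4-fold higher number from compound 2 to compound 3 (0.16 log units; that floor lies within the scatter), the first comparison at this position with the rest of the molecule held constant. Compound 3 gives > 20000 nM, which is a limit of the assay and not a number. Fluoro in place of methyl gives no sign of a lower number here, but the size of the step stays unfixed because the series crowds at the top of the readable range: the limit of > 20000 nM in this assay, at which 2 of the 3 values shown sit.

From the compounds shown here alone, whether the true step lies beyond the usual scatter remains open, since only its floor is known and that floor lies within it. Also open, going by these compounds, is how this position responds to a group such as an amine, a carboxylic acid or a longer chain, and whether any such group brings the number clearly below that of compound 2.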